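The source may hold more compounds than are shown below. What is called first, only, known or untested is meant among the compounds shown, and "the series" means these compounds.

Compound 1 `CC(C)[C@H](NC(=O)COc1cccc2ccccc12)C(=O)N[C@@H](CC(=O)O)C(=O)CSc1nc(-c2ccccc2)no1` gives 102000 nM in a functional assay on Jurkat cells (Homo sapiens) for inhibition; a higher number here means a weaker inhibitor, a lower number a stronger inhibitor. Compound 2 `Cc1cc(OCC(=O)[C@H](CC(=O)O)NC(=O)[C@@H](NC(=O)COc2cccc3ccccc23)C(C)C)nc(C)n1` differs from it only at one place, and that change produced an at least 1.9-fold higher number from compound 1 to compound 2 (0.29 log units; that floor lies within the scatter). For compound 2 this assay reports no number but a limit, > 200000 nM, which is the limit of > 200000 nM in this assay, at which 1 of the 2 values shown sits. Compound 3 `CC(C)[C@H](NC(=O)COc1cccc2ccccc12)C(=O)N[C@@H](CC(=O)O)C(=O)COn1nnc2ccccc2c1=O` is not yet measured; it carries a group of 11 heavy atoms (7 carbon, 3 nitrogen, 1 oxygen; one six-membered aromatic ring of carbon only, one six-membered aromatic ring with 3 hetero atoms) in place of a group of 8 heavy atoms (6 carbon, 2 nitrogen; one six-membered aromatic ring with 2 hetero atoms), on an oxygen on a saturated carbon. Among the compounds with values here, no measured step covers this change, and the one step known sits at a limit, so it is expected that compound 3 shows no step beyond the scatter, an at least 1.1-fold lower number from compound 2 to compound 3 (0.04 log units; that floor lies within the scatter). Compound 3 is therefore estimated at 180000 nM, within a range from 60000 nM to 500000 nM.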

Compound 3, half-maximal inhibitory concentration: 137000 nM
For compound 3 the middle estimate is 1.3-fold (0.12 log units) above the measured one; low and high end bracket the measured number.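

At the saturated chain carbon bound to a carbonyl carbon, exchanging the whole group gives a 1.3-fold higher number from compound 1 to compound 3 (0.13 log units; within the scatter), so the sulfur-linked group of compound 1 and the oxygen-linked group of compound 3 cannot be told apart in this assay. The other new step is only a floor, an at least 1.4-fold lower number from compound 2 to compound 3 (0.16 log units; that floor lies within the scatter), and it leaves the true size of that change unknown. Compound 2 gives no number but a limit: the limit of > 200000 nM in this assay, at which 1 of the 3 values shown sits.

No step shown is established beyond the scatter. As far as these compounds go, whether a fluorine atom or an amine at this place would give such a step remains open.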